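Benzylamino in place of phenyl in compound 1

This account rests on a few compounds, and the source may have more. Where it says the series, first, only, none or still open, it means among the compounds named here.

Compound 1 `CC1=CC[C@H]2[C@H](CC[C@]2(C)O)C(C)(C)[C@@H]1CC[C@H]1[C@]2(C)CC[C@H](OC(=O)c3ccccc3)C(C)(C)O[C@H]2CC[C@@]1(C)O` gives 16100 nM
Compound 2 `CC1=CC[C@H]2[C@@H]1CC=C(C)[C@@H](CC[C@H]1[C@]3(C)CC[C@H](OC(=O)c4ccc(C)cc4)C(C)(C)O[C@H]3CC[C@@]1(C)O)C2(C)C` gives 32700 nM
Compound 3 `CC1=CC[C@H]2[C@@H]1CC=C(C)[C@@H](CC[C@H]1[C@]3(C)CC[C@H](OC(=O)c4ccc(Cl)cc4)C(C)(C)O[C@H]3CC[C@@]1(C)O)C2(C)C` gives 12700 nM

In a functional assay on MDA-MB-231 cells (Homo sapiens) for antiproliferative activity, read by MTT assay, with a stated time of 72 h (on this read-out higher numbers stand for weaker inhibition and lower numbers for stronger inhibition), compound 1 gives 16100 nM and lies within the scatter of compound 3 at 12700 nM on the same read-out. Compound 2 stands higher at 32700 nM and is beyond the scatter from compound 1.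

Compound 4 `CC1=CC[C@H]2[C@H](CC[C@]2(C)O)C(C)(C)[C@@H]1CC[C@H]1[C@]2(C)CC[C@H](OC(=O)NCc3ccccc3)C(C)(C)O[C@H]2CC[C@@]1(C)O` differs from compound 1 in one place, benzylamino in place of phenyl on a carbonyl carbon and so benzoyloxy becomes (benzylcarbamoyl)oxy. Within the data shown here, no measured step covers this change. Among the measured compounds shown here, the only step in hand, a 2.6-fold lower number from compound 2 to compound 3 (0.41 log units; beyond the scatter) for chloro in place of methyl on an aromatic carbon, is modest and concerns a different group. It suggests a rough size for a change in this part of the molecule but gives no direction for compound 4. In this assay no step beyond the scatter is therefore expected, and the estimated change is a 1.1-fold higher number from compound 1 to compound 4 (0.05 log units; within the scatter) with considerable uncertainty either way. For compound 4 the expected value is 18000 nM and it is estimated to fall between 7000 nM and 45000 nM on repeated measurement.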

Compound 4, half-maximal inhibitory concentration: 40300 nM
Beside the measured number, compound 4's estimate is 2.2-fold (0.35 log units) below it; low and high end bracket the measured number.
By their numbers in this assay, from the lowest: compounds 3 and 1 (each within the scatter of the next); then compounds 2 and 4 (each within the scatter of the next).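

In this assay, benzylamino in place of phenyl on a carbonyl carbon gives a 2.5-fold higher number from compound 1 to compound 4 (0.40 log units; beyond the scatter), a modest weakening of inhibition that lies beyond the scatter. Among these compounds, this is the first sign that this place responds to a change in what links the aromatic ring to the carbonyl carbon, whereas the earlier step, a 2.6-fold lower number from compound 2 to compound 3 (0.41 log units; beyond the scatter), changed only a substituent on an aromatic carbon and kept the benzoyloxy link in place. The change enlarges the group and adds a nitrogen and a hydrogen-bond donor while keeping the aromatic ring, but nothing available accounts for the higher number.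

Among the compounds shown here, the single step cannot separate the effect of the nitrogen from that of the added carbon, and phenylamino or benzyloxy on the same carbonyl carbon would be needed to tell the two apart. Going by these compounds, it also remains open whether a chloro group on the aromatic ring of compound 4 would lower the number, or whether a saturated ring such as cyclohexylamino would be tolerated in place of benzylamino.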